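Thiazole in Place of Acetamido: Expected Cytotoxicity of Compound 3

The compounds below may be only part of what the source reports. "The series", "measured", "known", "first", "only" and "open" are said of these compounds alone.

Measured compounds:
compound 1, `CC(=O)Nc1cccc(C(=O)N2CCCC(C(=O)Nc3ccc(Cl)cc3)C2)c1`, 4%
compound 2, `C=CCOc1cccc(NC(=O)C2CCCN(C(=O)c3cc(C(F)(F)F)cc(C(F)(F)F)c3)C2)c1`, 0%

In an ADME assay on PC-3 cells (Homo sapiens) for cytotoxicity, read by WST assay, tested at 100 uM (a higher number here means more inhibition at the concentration tested (going by the name of the read-out), a lower number less inhibition), compound 1 gives 4%, and compound 2 gives 0%. The two numbers lie within the usual scatter of each other, so neither compound shows a meaningful effect at the tested concentration. Compound 3 `Cc1nc(-c2cccc(C(=O)N3CCCC(C(=O)Nc4ccc(Cl)cc4)C3)c2)cs1` has not yet been measured. It differs from compound 1 by 2-methyl-1,3-thiazol-4-yl in place of acetamido on an aromatic carbon. Among the measured compounds shown here, no pair of measured compounds shows the effect of this change, so its size cannot be read from the data; in this assay a step beyond the scatter is not expected in either direction. Compound 3 is expected to give 8%, in a range from -5% to 25%. That estimate means an expected step of a number 4 percentage points higher from compound 1 to compound 3 (within the scatter).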

Compound 3, a percentage reported as inhibition, at one concentration (the size of the read-out at that concentration, not a potency): 1%
Compound 3: middle estimate off by 7 percentage points, on the high side; measured number inside the range.
By their numbers in this assay, from the lowest: compounds 2, 3 and 1 (each within the scatter of the next).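

In this assay, among the compounds shown here, 2-methyl-1,3-thiazol-4-yl in place of acetamido on this aromatic carbon gives a number 3 percentage points lower from compound 1 to compound 3 (within the scatter), the first view of any change at this position. Replacing an open group bearing a hydrogen-bond donor with a five-membered aromatic ring that has no such donor therefore leaves the two compounds indistinguishable here. No supporting measurement bears on why this is so. On these data alone, whether any group at this position can produce a step beyond the scatter remains open. An amine or a carboxylic acid on this aromatic carbon would test that.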